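Fluorine shift on the aniline ring: notes on compound 4

This account rests on a few compounds, and the source may have more. Where it says the series, first, only, none or still open, it means among the compounds named here.

Measured in a functional assay on ECa-109 cells for inhibition, with ECa-109 cell line (Homo sapiens) as the target, read by sulforhodamine B assay; on this read-out higher numbers stand for weaker inhibition and lower numbers for stronger inhibition:
- compound 1 `O=C1C(Nc2ccc(I)cc2)=CC(=O)c2c1nc1n2[C@H]2OC[C@@H](O)[C@H]2OC1`: 2530 nM
- compound 2 `O=C1C=C(Nc2ccccc2F)C(=O)c2c1nc1n2[C@H]2OC[C@@H](O)[C@H]2OC1`: 2760 nM
- compound 3 `O=C1C(N2CCCC2)=CC(=O)c2c1nc1n2[C@H]2OC[C@@H](O)[C@H]2OC1`: > 16000 nM (a limit of the assay)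

Compound 1 at 2530 nM and compound 2 at 2760 nM lie within the scatter of each other. Compound 4 `O=C1C=C(Nc2cccc(F)c2)C(=O)c2c1nc1n2[C@H]2OC[C@@H](O)[C@H]2OC1` carries 3-fluorophenyl in place of 2-fluorophenyl on an amine nitrogen.

Among the measured compounds shown here, the only measured step is an at least 6.3-fold higher number from compound 1 to compound 3 (0.80 log units; beyond the scatter), with pyrrolidin-1-yl in place of (4-iodophenyl)amino on a double-bonded ring carbon. That step exchanges the whole aryl amine, whereas compound 4 keeps a fluorophenyl on the amine nitrogen, so it bears only weakly on this change. For the measured compounds named here, no measured step starts from compound 2, and no step beyond the scatter is expected in this assay. The estimate is a 1.0-fold higher number from compound 2 to compound 4 (0.01 log units; within the scatter). For compound 4 the expected value is 2800 nM, with an estimated range of 1200 nM to 6500 nM.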

Compound 4, half-maximal inhibitory concentration: 7030 nM
Estimate against measurement, compound 4: 2.5-fold (0.40 log units) below; the whole stated range lies below it.
By their numbers in this assay, from the lowest: compounds 1 and 2 (each within the scatter of the next); then compound 4. At a limit, above all of these: compound 3.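

In this assay, 3-fluorophenyl in place of 2-fluorophenyl on the amine nitrogen gives a 2.5-fold higher number from compound 2 to compound 4 (0.41 log units; beyond the scatter) and thus weaker inhibition, although the group leaving and the group entering hold the same atoms, joined differently. The earlier compounds shown here changed the whole amine substituent, whereas this pair shows that the read-out at this position also responds when only the place of the fluorine on the phenyl ring changes. No data shown here account for this difference.

The compounds shown leave open how 4-fluorophenyl would read in this series, and so whether the fluorine shift continues in the same direction. They also leave open whether 3-chlorophenyl or 3-methoxyphenyl on the same amine nitrogen would follow 3-fluorophenyl, or whether this step is particular to fluorine.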